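This account rests on a few compounds, and the source may have more. Where it says the series, first, only, none or still open, it means among the compounds named here.

Measured so far in an assay on isolated protein for inhibition of aldehyde dehydrogenase 1A1 (Homo sapiens), read by spectrophotometry, tested at 10 uM; on this read-out lower numbers stand for less inhibition and higher numbers for more inhibition at the one concentration tested (going by the name of the read-out):
compound 1, `Cc1cccc(Cn2c(CN3CCN(C(=O)c4ccc([N+](=O)[O-])cc4)CC3)nc3ccccc32)c1`: 24.3%
compound 2, `Cc1cccc(Cn2c(CN3CCN(C(=O)C4CCCCC4)CC3)nc3ccccc32)c1`: 31.9%
compound 3, `Cc1cccc(Cn2c(CN3CCN(C(=O)c4ccco4)CC3)nc3ccccc32)c1`: 73.2%

Compound 3 stands highest of the three numbers; the steps up to it are large, a number 48.9 percentage points higher from compound 1 to compound 3 (beyond the scatter) and a number 41.3 percentage points higher from compound 2 to compound 3 (beyond the scatter), both beyond the scatter. Between the other two the step is a number 7.6 percentage points higher from compound 1 to compound 2 (within the scatter), within the scatter, so compound 1 and compound 2 cannot be ordered against each other.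

Compound 4, `Cc1cccc(Cn2c(CN3CCN(C(=O)c4ccc(Br)cc4)CC3)nc3ccccc32)c1`, differs from compound 3 by 4-bromophenyl in place of furan-2-yl on a carbonyl carbon. The step that bears most directly is the one from the other six-membered aromatic ring of carbon only, compound 1 with 4-nitrophenyl, to compound 3 with furan-2-yl, a number 48.9 percentage points higher from compound 1 to compound 3 (beyond the scatter). Of the three measured groups on this carbonyl carbon, only furan-2-yl gives a high number; 4-nitrophenyl and cyclohexyl sit low and within the scatter of each other. Since compound 4 gives up furan-2-yl for a six-membered carbon ring, a large downward step is expected, a number 40.2 percentage points lower from compound 3 to compound 4 (beyond the scatter), landing near compound 1 and compound 2. Compound 4 is estimated at 33% in this assay, expected range 15% to 58%.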

Compound 4, a percentage reported as inhibition, at one concentration (the size of the read-out at that concentration, not a potency): 25.8%
Compound 4: the middle estimate sits 7.2 percentage points above what was measured; the measured number falls inside the stated range.
By their numbers in this assay, from the lowest: compounds 1, 4 and 2 (each within the scatter of the next); then compound 3.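

In this assay, on a carbonyl carbon whose other neighbour is an amide-type nitrogen in a ring, the change to 4-bromophenyl gives a number 47.4 percentage points lower from compound 3 to compound 4 (beyond the scatter) and so confirms that the high number does not carry over to this six-membered aromatic ring of carbon only. Bromo in place of nitro on an aromatic carbon gives a number 1.5 percentage points higher from compound 1 to compound 4 (within the scatter) and 4-bromophenyl in place of cyclohexyl gives a number 6.1 percentage points lower from compound 2 to compound 4 (within the scatter) so neither change separates these compounds. Across the four compounds, furan-2-yl alone stands apart from the three six-membered rings, and none goes against this.

Going by these compounds, whether thiophen-2-yl or unsubstituted phenyl would sit with furan-2-yl or with the six-membered rings stays open. Nothing at hand accounts for the gap between furan-2-yl and those rings.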